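This account rests on a few compounds, and the source may have more. Where it says the series, first, only, none or still open, it means among the compounds named here.

Measured so far:
Compound 1 `COc1ccc(-c2nc(SCC(=O)c3sc(-c4ccccc4)nc3C)nc(N)c2C#N)cc1`: in a functional assay on U-87MG ATCC cells for antiproliferative activity against U-87 MG (Homo sapiens), read by MTT assay, with a stated time of 48 h, tested at 100 uM (a lower number here means a stronger effect, a higher number a weaker effect of the compound at the concentration tested), compound 1 gives 17.2%.
Compound 2 `COc1cccc(-c2nc(SCC(=O)c3sc(-c4ccccc4)nc3C)[nH]c(=O)c2C#N)c1`: in this assay compound 2 gives 21.8%.

Compound 1 stands at the lower of these two numbers, yet compound 2 lies within the scatter of it, so the two cannot be told apart. Compound 3 `Cc1nc(-c2ccccc2)sc1C(=O)CSc1nc(N)c(C#N)c(-c2ccccc2)n1` is not yet measured. It differs from compound 1 in one place: hydrogen in place of methoxy on an aromatic carbon. For the measured compounds named here, no step between measured compounds covers such a change, so there is no direct guide. The step expected from compound 1 to compound 3 in this assay is a number 7.8 percentage points higher from compound 1 to compound 3 (within the scatter), a small rise that may not exceed the scatter. Compound 3 is therefore estimated at 25%, within 12% to 45%.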

Compound 3, a percentage reported as activity, at one concentration (the size of the read-out at that concentration, not a potency): 6.48%
Compound 3: middle estimate off by 18.5 percentage points, on the high side; measured number outside the range, below it.
By their numbers in this assay, from the lowest: compound 3; then compounds 1 and 2 (each within the scatter of the next).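

Going from 4-methoxyphenyl to phenyl gives the first change here that can be read: in this assay, the number falls, a number 10.7 percentage points lower from compound 1 to compound 3 (beyond the scatter). Since a lower number means a stronger effect at the concentration tested, the methoxy group is not needed at this place for the effect, and the compound with hydrogen there does better. Nothing at hand gives a reason for this step.

From the compounds shown here alone, whether chlorine, a hydroxyl or an amine at this place would give a lower or higher number stays open. Also open, going by these compounds, is whether the same change would have a similar effect on the core of compound 2.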